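The compounds below may be only part of what the source reports. "The series", "measured", "known", "first", "only" and "open" are said of these compounds alone.

Compound 1 `COc1ccc2cc(C(C)CC(C)=O)ccc2c1` carries a methoxy on its fused aromatic core and a branched ketone side chain. In a functional assay on the whole organism (strain Wistar) for inhibition, with Rattus norvegicus as the target, with a stated time of 5 days, at a dose of 50 mg/kg by the oral route (on this read-out lower numbers stand for less inhibition and higher numbers for more inhibition at the one dose given (going by the name of the read-out)), compound 1 gives 24%, the highest of the three numbers recorded. Compound 2 `COc1ccc2cc(CC(C)C(C)=O)ccc2c1` gives 7% and compound 3 `CCC(=O)CCc1ccc2cc(OC)ccc2c1` gives 7%. The step of a number 17 percentage points lower from compound 1 to compound 2 (beyond the scatter) and the step of a number 17 percentage points lower from compound 1 to compound 3 (beyond the scatter) both rework the side chain; the step of no change at the digits printed from compound 2 to compound 3 (within the scatter) shows that propanoylmethyl in place of 1-acetylethyl changes nothing beyond the scatter.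

Going by the values given here, compound 4 `CC(=O)CC(C)c1ccc2cc(C)ccc2c1` differs from compound 1 in a different place: methyl in place of methoxy on an aromatic carbon None of the measured steps touches the methoxy, so there is no step that bears directly on this change, and the side chain of compound 4 is kept as in compound 1. Among the compounds with values here, with no comparable step to lean on, the change is expected to give a step of a number 4 percentage points lower from compound 1 to compound 4 (within the scatter) in this assay, that is, nothing clearly beyond the scatter. Compound 4 is therefore estimated at 20%, within a range from 5% to 40%.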

Compound 4, a percentage reported as inhibition, in the whole organism at one dose (the size of the read-out at that dose, not a potency): 11%
Compound 4: the middle estimate sits 9 percentage points above what was measured, within the range that was stated.
By their numbers in this assay, from the lowest: compounds 2, 3 and 4 (each within the scatter of the next); then compound 1.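

The swap of methoxy for methyl on this aromatic carbon gives a number 13 percentage points lower from compound 1 to compound 4 (beyond the scatter) in this assay, a modest step. Going by these compounds alone, until now every measured step had reworked the side chain while the methoxy stayed in place, so this is the first sign that the read-out also responds to the group at this position, with the side chain of compound 1 kept unchanged. Nothing measured here accounts for the step, and no separate measurement bears on it.

With only methoxy and methyl seen at this position, the compounds shown leave open how a hydroxy group, an ethoxy group or a chlorine atom would read there. They also leave open whether methyl in place of methoxy would give a similar step on the side chains of compound 2 and compound 3.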